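This account rests on a few compounds, and the source may have more. Where it says the series, first, only, none or still open, it means among the compounds named here.

Measured so far in an ADME assay on HepG2 2.2.15 cells (Homo sapiens) for cytotoxicity, read by MTT assay, with stated times of 48 h and 9 days; a higher number here means that more compound is tolerated, a lower number that less compound is tolerated:

- compound 1 `COc1ccc2c(=O)c(/C=C/C(=O)Nc3cccc(C)c3)coc2c1` gives 554000 nM
- compound 2 `COc1cccc(NC(=O)/C=C/c2coc3cc(OC)ccc3c2=O)c1` gives 1130000 nM
- compound 3 `COc1ccc(NC(=O)/C=C/c2coc3cc(OC)ccc3c2=O)cc1` gives 718000 nM

Among these three, compound 3 sits between the other two; its gaps to compound 1 and to compound 2 both fall within the usual scatter, so no order among them can be claimed. For the measured compounds named here, the only step beyond the scatter is a 2.0-fold higher number from compound 1 to compound 2 (0.31 log units; beyond the scatter), a swap of methyl for methoxy. Compound 4 `COc1ccc2c(=O)c(/C=C/C(=O)Nc3ccc(Cl)cc3)coc2c1` differs from compound 3 by chloro in place of methoxy on an aromatic carbon. Going by the values given here, no measured step swaps methoxy for chloro, so nothing directly bears on it; the swaps of ring substituents seen here, a 1.6-fold lower number from compound 2 to compound 3 (0.20 log units; within the scatter) and a 1.3-fold higher number from compound 1 to compound 3 (0.11 log units; within the scatter), stayed small. The expected step is therefore a 1.2-fold lower number from compound 3 to compound 4 (0.08 log units; within the scatter), none beyond the scatter. Compound 4 is estimated at 600000 nM, between 300000 nM and 1300000 nM.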

Compound 4, half-maximal cytotoxic concentration: 272000 nM
Estimate against measurement, compound 4: 2.2-fold (0.34 log units) above; the whole stated range lies above it.
By their numbers in this assay, from the lowest: compound 4; then compounds 1, 3 and 2 (each within the scatter of the next, the first and the last beyond it).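

Compound 4 stands apart from each of the other compounds in this assay (a 2.6-fold lower number from compound 3 to compound 4 (0.42 log units; beyond the scatter); a 4.2-fold lower number from compound 2 to compound 4 (0.62 log units; beyond the scatter); a 2.0-fold lower number from compound 1 to compound 4 (0.31 log units; beyond the scatter)). It therefore has the lowest number of the four, showing that changing methoxy to chloro on this aromatic carbon can clearly lower the amount of compound tolerated. Nothing available explains this drop.

Going by these compounds, it remains open whether bromo, fluoro or an amine on the same carbon would give a similar number. On these data alone, it is also open whether chloro would act the same way elsewhere on this ring.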